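Swapping naphthalen-1-yl for naphthalen-2-yl in a cytotoxic series

This account rests on a few compounds, and the source may have more. Where it says the series, first, only, none or still open, it means among the compounds named here.

In a functional assay on RPMI 8402 cells (Homo sapiens) for cytotoxicity (a higher number here means a weaker inhibitor, a lower number a stronger inhibitor), compound 1 `N#Cc1ccc2[nH]c(-c3ccc4[nH]c(-c5ccc6ccccc6c5)nc4c3)nc2c1` gives 130 nM, compound 2 `Cc1ccccc1-c1nc2cc(-c3nc4cc(C(N)=O)ccc4[nH]3)ccc2[nH]1` gives 8200 nM and compound 3 `NC(=O)c1ccc2[nH]c(-c3ccc4[nH]c(-c5cccc6ccccc56)nc4c3)nc2c1` gives 3700 nM. Compound 3 therefore sits in the middle, with the second highest of the three numbers. Compound 4 `NC(=O)c1ccc2[nH]c(-c3ccc4[nH]c(-c5ccc6ccccc6c5)nc4c3)nc2c1` has the same atoms as compound 3, joined differently, with naphthalen-2-yl in place of naphthalen-1-yl on an aromatic carbon.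

One measured step changes this same group: a 2.2-fold lower number from compound 2 to compound 3 (0.35 log units; beyond the scatter), with naphthalen-1-yl in place of 2-methylphenyl. It says little about naphthalen-2-yl. Compound 1 already carries naphthalen-2-yl and reaches 130 nM, but it also has a nitrile where compound 3 has an amide, so the gap between these two cannot be split between the two differences. A lower number is expected, though not one as low as that of compound 1, and the expected change is a 4.6-fold lower number from compound 3 to compound 4 (0.67 log units; beyond the scatter). For compound 4 the estimated value is 800 nM, with an expected range of 200 nM to 3000 nM.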

Compound 4, half-maximal inhibitory concentration: 740 nM
Compound 4: middle estimate off by 1.1-fold (0.03 log units), on the high side, within the range that was stated.
By their numbers in this assay, from the lowest: compound 1; then compound 4; then compound 3; then compound 2.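

In this assay, naphthalen-2-yl in place of naphthalen-1-yl gives a 5.0-fold lower number from compound 3 to compound 4 (0.70 log units; beyond the scatter), so with the same atoms, the point of attachment alone changes the result at this aromatic carbon between two ring nitrogen atoms. Compared with 2-methylphenyl, naphthalen-2-yl gives an 11-fold lower number from compound 2 to compound 4 (1.04 log units; beyond the scatter), a larger change than the earlier step with naphthalen-1-yl, a 2.2-fold lower number from compound 2 to compound 3 (0.35 log units; beyond the scatter). With naphthalen-2-yl held constant, the effect of the other group can now be read separately: carbamoyl in place of cyano gives a 5.7-fold higher number from compound 1 to compound 4 (0.76 log units; beyond the scatter), so the nitrile compound keeps a clear advantage over the amide.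

Nothing available explains why the two attachment points differ. From the compounds shown here alone, it also remains open how a carboxylic acid or an aminomethyl group would compare with the carbamoyl and cyano groups on the naphthalen-2-yl compounds.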